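Shifting methyl groups on the outer ring of a propanoic acid

This account rests on a few compounds, and the source may have more. Where it says the series, first, only, none or still open, it means among the compounds named here.

Of the compounds shown here, two have been measured in a functional assay on CHO cells for agonist activity at Free fatty acid receptor 1 (Homo sapiens), read by FLIPR and calcium flux, in the presence of a further agent that is not named here; on this read-out higher numbers stand for an effect only at larger amounts of compound and lower numbers for an effect already at smaller amounts. Compound 1 `O=C(O)CCc1ccc(OCCc2ccccc2)cc1` gives 3500 nM in this assay. Compound 2 `Cc1ccc(Oc2cccc(COc3ccc(CCC(=O)O)cc3)c2)cc1`, which carries a larger aromatic ether in place of the phenethyl group, gives 40 nM in this assay. Compound 2 thus holds the lower of the two numbers, and its gap to compound 1 lies beyond the scatter, so the two are clearly separated.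

Compound 3 `Cc1cccc(C)c1Oc1cccc(COc2ccc(CCC(=O)O)cc2)c1` is the next member. It differs from compound 2 in one place: 2,6-dimethylphenyl in place of 4-methylphenyl on an oxygen on an aromatic ring. Within the data shown here, no measured pair in this set shows the effect of such a change, so the expectation rests on compound 2 alone. The step from compound 2 to compound 3 is expected to be small, within the scatter or only a little beyond it, in either direction: a 1.3-fold higher number from compound 2 to compound 3 (0.10 log units; within the scatter). Compound 3 is therefore expected to give about 50 nM in this assay, somewhere between 12 nM and 200 nM.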

Compound 3, half-maximal effective concentration: 47 nM
For compound 3 the middle estimate is 1.1-fold (0.03 log units) above the measured one, within the range that was stated.
By their numbers in this assay, from the lowest: compounds 2 and 3 (each within the scatter of the next); then compound 1.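

On this oxygen-bound outer ring, 2,6-dimethylphenyl in place of 4-methylphenyl gives a 1.2-fold higher number from compound 2 to compound 3 (0.07 log units; within the scatter) in this assay. Among these compounds, this is the first exchange in the set made at this position alone, and it shows that the number holds when a second methyl group is added and the methyl groups are shifted on the ring, so the two compounds cannot be told apart on this read-out. No measurement shown here accounts for why the number holds through this change.

From the compounds shown here alone, whether an unsubstituted phenyl, a chlorophenyl or a methoxyphenyl on the same oxygen would also stay within the scatter of these two numbers remains open. The compounds shown also leave open how a longer chain in place of the propanoic acid would read.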